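A few compounds are considered here, and "the series" means these few. Any claim that something is new, unique, unknown or untested is made for them only; others in the source may bear on it.

Of the compounds shown here, three of a shared core have been tested in a functional assay on K562 cells (Homo sapiens) for inhibition, read by trypan blue exclusion, with a stated time of 72 h; a lower number here means a stronger inhibitor, a higher number a weaker inhibitor. Compound 1 `Cn1c(=O)c(S(=O)(=O)c2ccc(F)cc2)cc2cnc(Nc3cccc4[nH]ccc34)nc21` gives 750 nM, compound 2 `O=c1c(S(=O)(=O)c2ccc(F)cc2F)cc2cnc(Nc3ccc4[nH]ccc4c3)nc2n1C1CC1` gives 500 nM, and compound 3 `Cn1ccc2cc(Nc3ncc4cc(S(=O)(=O)c5ccc(F)cc5F)c(=O)n(C)c4n3)ccc21` gives 750 nM. Compound 2 has the smallest of these three numbers, yet both compound 1 and compound 3 lie within the usual scatter of it, so the three cannot be told apart on these data.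

Compound 4 `CCCn1c(=O)c(S(=O)(=O)c2ccc(F)cc2F)cc2cnc(Nc3ccc4[nH]ccc4c3)nc21` has not yet been measured in this assay. It differs from compound 2 in one place: propyl in place of cyclopropyl on an aromatic nitrogen. Among the measured compounds shown here, no measured pair shows such a swap, so nothing indicates a change beyond the scatter. The step of a 1.1-fold higher number from compound 2 to compound 4 (0.04 log units; within the scatter) is therefore expected to be small. Compound 4 is expected to give about 550 nM, with a likely range from 250 nM to 1200 nM.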

Compound 4, half-maximal inhibitory concentration: 1000 nM
The estimate for compound 4 lay 1.8-fold (0.26 log units) below the measured number; low and high end bracket the measured number.
By their numbers in this assay, from the lowest: compounds 2, 1, 3 and 4 (each within the scatter of the next).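

In this assay, among the compounds shown here, the swap of cyclopropyl for propyl on the aromatic nitrogen gives the first single-place step at this position: a 2.0-fold higher number from compound 2 to compound 4 (0.30 log units; within the scatter). Losing the three-membered ring while keeping the same count of carbon atoms therefore leaves the number within the scatter, so this pair does not show that the ring matters here. No measurement at hand bears on the reason for this result.

On these data alone, whether a longer chain, or a chain ending in an amine or a carboxylic acid, would move the number beyond the scatter remains open.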